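A few compounds are considered here, and "the series" means these few. Any claim that something is new, unique, unknown or untested is made for them only; others in the source may bear on it.

Working notes on the series. In an assay on Sf9 cells for inhibition of protein deacetylase HDAC6 (Homo sapiens), read by fluorescence, with a stated time of 40 min, tested at 100 nM (a higher number here means more inhibition at the concentration tested (going by the name of the read-out), a lower number less inhibition), compound 1 `O=C(NO)c1ccc(NCc2nc(-c3ccccc3)nn2-c2ccccc2Cl)cc1` gives 64.6%, the highest of the three numbers in hand, though compound 2 `O=C(NO)c1ccc(NCc2nc(-c3ccco3)nn2-c2ccccc2)cc1` gives 59.9% and compound 3 `O=C(NO)c1ccc(NCc2nc(-c3ccccn3)nn2-c2ccccc2)cc1` gives 58.6%, both within the scatter of compound 1. Among the compounds with values here, the only measured step, a number 1.3 percentage points lower from compound 2 to compound 3 (within the scatter), changes the group on an aromatic carbon and not the group on the aromatic nitrogen. Compound 4 `O=C(NO)c1ccc(NCc2nc(-c3ccccc3)nn2-c2ccc(F)cc2)cc1` differs from compound 1 by 4-fluorophenyl in place of 2-chlorophenyl on an aromatic nitrogen. Within the data shown here, no measured step touches this position, so no change beyond the scatter is expected, and the estimated step is a number 4.6 percentage points lower from compound 1 to compound 4 (within the scatter). Compound 4 is expected to give 60%, in the range 45% to 75%.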

Compound 4, a percentage reported as inhibition, at one concentration (the size of the read-out at that concentration, not a potency): 67.6%
For compound 4 the middle estimate is 7.6 percentage points below the measured one; measured number inside the range.
By their numbers in this assay, from the lowest: compounds 3, 2, 1 and 4 (each within the scatter of the next).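

In this assay the position on the aromatic nitrogen now has a measured step, with a number 3 percentage points higher from compound 1 to compound 4 (within the scatter) when 4-fluorophenyl replaces 2-chlorophenyl. On this shared core, the number in this assay is therefore level across this exchange of one halogen-bearing phenyl group for the other at the single concentration tested. Nothing in hand explains the result.

The compounds shown leave open whether a group other than a substituted phenyl, such as benzyl or a longer alkyl chain, would stay within the scatter at this position. They also leave open how a phenyl group bearing a carboxylic acid would read here.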